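This account rests on a few compounds, and the source may have more. Where it says the series, first, only, none or still open, it means among the compounds named here.

Of the compounds shown here, three have so far been measured in a functional assay on the whole organism (Tail, strain ICR) with Mus musculus as the target, in the tail flick test, with a stated time of 60 min, at a dose of 25 umol/kg by the oral route; a higher number here means a stronger effect of the compound at the dose given, a lower number a weaker effect. Compound 1 `O=C(O)[C@@H]1CCCN1C(=O)CN(c1nc(Cl)nc2[nH]cnc12)C1CC1` gives 34.9%. Compound 2 `N=C(N)NCCC[C@H](NC(=O)CN(c1nc(Cl)nc2[nH]cnc12)C1CC1)C(=O)OCc1ccccc1` gives 30.6%. Compound 3 `O=C(CN(c1ncnc2c1ncn2C1CCCCO1)C1CC1)N[C@@H](CO)C(=O)OCc1ccccc1` gives 46.7%, the highest of the three numbers; its gap to compound 1 and its gap to compound 2 both lie beyond the scatter of repeated measurements. Compound 4 `CC(C)(C)OC(=O)NCCCC[C@H](NC(=O)CN(c1ncnc2c1ncn2C1CCCCO1)C1CC1)C(=O)OCc1ccccc1` has not yet been measured in this assay. It differs from compound 3 in one place: 3-((tert-butoxycarbonyl)amino)propyl in place of hydroxy on a saturated chain carbon, two bonds along the chain from an amide-type nitrogen and a carbonyl carbon. Among the measured compounds shown here, no step between two measured compounds that differ in a single place is known, so the size of this kind of change cannot be read from earlier pairs. The three measured values all sit in a moderate band, and nothing among them points to a large move in either direction. The step of a number 6.7 percentage points lower from compound 3 to compound 4 (within the scatter) is therefore expected to be small, most likely a slight fall or none beyond the scatter. Compound 4 is estimated to give 40%, with a range from 22% to 58%.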

Compound 4, a percentage reported as activity, at one dose (the size of the read-out at that dose, not a potency): 32.7%
Beside the measured number, compound 4's estimate is 7.3 percentage points above it, within the range that was stated.
By their numbers in this assay, from the lowest: compounds 2, 4 and 1 (each within the scatter of the next); then compound 3.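

In this assay, among the compounds shown here, this is the first comparison of two compounds that differ in a single place, so it gives the first direct reading for this position, a saturated chain carbon two bonds along the chain from an amide-type nitrogen and a carbonyl carbon. Replacing hydroxy with 3-((tert-butoxycarbonyl)amino)propyl gives a number 14 percentage points lower from compound 3 to compound 4 (beyond the scatter), so the read-out at this dose does respond to what sits here. The effect falls but does not vanish, since compound 4 still gives 32.7%, and no measurement at hand explains the fall.

This single step changes the chain and its tert-butoxycarbonyl end together, so their shares in the fall cannot be separated. A free primary amine at the end of the same chain, or a plain methyl at this position, would be needed to tell them apart.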